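From Methylsulfanyl to Methylsulfonyl in a Mouse Antagonist Series

The source may report more compounds than this note shows. Statements on the series, on what has been measured and on what is new or still open speak of the compounds shown alone.

In a functional assay on the whole organism for antagonist activity, with Mus musculus as the target (on this read-out lower numbers stand for an effect already at smaller amounts and higher numbers for an effect only at larger amounts of compound), compound 2 (`CSc1nc(-c2ccc(Cl)cc2)nn1C`) gives > 200 mg/kg as a limit of the assay and not a number. Compound 2 therefore has no measured potency of its own and stands at the limit of > 200 mg/kg in this assay, at which 2 of the 2 values shown sit, in the small set available. Compound 3 (`Cn1nc(-c2ccc(Cl)cc2)nc1S(C)(=O)=O`) differs from compound 2 in one place, with methylsulfonyl in place of methylsulfanyl on an aromatic carbon. Among the measured compounds shown here, no measured step covers this change. Compound 1 (`Cn1nc(-c2ccccc2)nc1S(C)(=O)=O`) also carries methylsulfonyl and gives > 200 mg/kg as a limit. The expectation is therefore uncertain, but a step toward smaller amounts is expected in this assay and beyond the scatter, estimated as an at least 3.3-fold lower number from compound 2 to compound 3 (0.52 log units; beyond the scatter) on the structural change alone. For compound 3 the estimated dose is 60 mg/kg with an expected range from 20 mg/kg to 200 mg/kg here.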

Compound 3, dose for half-maximal effect: > 200 mg/kg
Compound 3: a limit, no number (the forecaster's own chance of this, stated with the estimate: 30%); middle value at least 3.3-fold (0.52 log units) away from the limit.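

Among the compounds shown here, no step to compound 3 can be read from compound 2 or compound 1 in this assay, since all three compounds give only a limit: the limit of > 200 mg/kg in this assay, at which 3 of the 3 values shown sit. The compounds shown leave open what dose gives a half-maximal effect for any of them, and whether either change shifts it.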